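The compounds below may be only part of what the source reports. "The series", "measured", "known", "first", "only" and "open" are said of these compounds alone.

Of the compounds shown here, three have so far been measured in a functional assay on the whole organism for inhibition, with Brassica napus as the target, with a stated time of 72 h, tested at 100 mg/L; on this read-out lower numbers stand for less inhibition of growth and higher numbers for more inhibition of growth at the one concentration tested. Compound 2 `COc1cc(Cl)nc(NC(=S)NC(=O)c2c(-c3ccc(Cl)cc3Cl)noc2C)n1` gives 61%, and compound 1 `COc1cc(SC)nc(NC(=S)NC(=O)c2c(-c3ccc(Cl)cc3Cl)noc2C)n1` gives 69.2%. The change from compound 2 to compound 1 is methylsulfanyl in place of chloro on an aromatic carbon, and it made a step of a number 8.2 percentage points higher from compound 2 to compound 1 (within the scatter). Compound 3 `COc1cc(Cl)nc2n/c(=N/C(=O)c3c(-c4ccc(Cl)cc4Cl)noc3C)sn12` has a different core; how its core differs from that of compound 2 is not broken down here. In this assay compound 3 gives 70.8%. Compound 4 `COc1cc(SC)nc2n/c(=N/C(=O)c3c(-c4ccc(Cl)cc4Cl)noc3C)sn12` is not yet measured. It differs from compound 3 by methylsulfanyl in place of chloro on an aromatic carbon, the same kind of change, though here the place is part of a fused or bridged system of two rings, meta and para to a fused ring rather than meta to a large group. A step of a number 4.2 percentage points higher from compound 3 to compound 4 (within the scatter) is expected because the earlier step of the same kind a number 8.2 percentage points higher from compound 2 to compound 1 (within the scatter) was small. Compound 4 is therefore estimated at 75%, expected to fall between 60% and 88%.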

Compound 4, percent growth inhibition at one concentration: 75.8%
Beside the measured number, compound 4's estimate is 0.8 percentage points below it; low and high end bracket the measured number.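

Methylsulfanyl in place of chloro gives a number 5 percentage points higher from compound 3 to compound 4 (within the scatter) in this assay and this step cannot be told apart from the one seen on the other core: the same change on two cores in this assay, a number 8.2 percentage points higher (within the scatter) from compound 2 to compound 1 and a number 5 percentage points higher (within the scatter) from compound 3 to compound 4, 3.2 percentage points apart, within the scatter of two such steps. So the change behaves alike on the two cores shown, but each step lies within the scatter, and neither shows that methylsulfanyl truly gives more growth inhibition than chloro. Two pairs tested at one concentration also say nothing about how the change would carry over to a further core.

Only chloro and methylsulfanyl appear at this place among the compounds shown. Going by these compounds, whether an amine or a longer chain such as ethylsulfanyl would give a clearly different reading on either core remains open.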